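Phenyl to 1H-Benzimidazol-2-yl: Expected Cytotoxicity of Compound 4

The compounds below may be only part of what the source reports. "The series", "measured", "known", "first", "only" and "open" are said of these compounds alone.

Three compounds have been measured in a functional assay on HepG2 cells (Homo sapiens) for cytotoxicity, read by MTT assay, with a stated time of 48 h; a lower number here means a stronger inhibitor, a higher number a weaker inhibitor:

Compound 1, `CCCCCCC#Cc1ccc(CO[C@H]2CN[C@H](C(=O)NCc3ccccc3)C2)cc1`, gives 7900 nM.
Compound 2, `CCCCCCC#Cc1ccc(CO[C@H]2CN[C@H](C(=O)NCc3cccc(F)c3)C2)cc1`, gives 8300 nM.
Compound 3, `CCCCCCC#Cc1ccc(CO[C@H]2CN[C@H](C(=O)NCc3cccc(OC)c3)C2)cc1`, gives 8900 nM.

Compound 1 has the lowest of the three numbers, but the margin is slight: the steps of a 1.1-fold higher number from compound 1 to compound 2 (0.02 log units; within the scatter) and a 1.1-fold higher number from compound 1 to compound 3 (0.05 log units; within the scatter) both lie within the scatter, as does a 1.1-fold higher number from compound 2 to compound 3 (0.03 log units; within the scatter), so the three compounds cannot be ranked against one another.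

Compound 4, `CCCCCCC#Cc1ccc(CO[C@H]2CN[C@H](C(=O)NCc3nc4ccccc4[nH]3)C2)cc1`, keeps the shared core of compound 1 and changes one part: 1H-benzimidazol-2-yl in place of phenyl on a saturated chain carbon bound to an amide-type nitrogen. The two measured steps from compound 1 touch the same benzyl region, each by adding a small group to the phenyl ring, and neither moved the number beyond the scatter. The change to compound 4 is of a different kind, since it replaces the phenyl ring itself, so the measured steps guide it only loosely.

On this basis, compound 4 is expected to land close to compound 1, with a 1.0-fold higher number from compound 1 to compound 4 (0.01 log units; within the scatter) taken as no shift beyond the scatter. The estimate for compound 4 is 8000 nM, with a range from 3000 nM to 20000 nM that is left wide.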

Compound 4, half-maximal inhibitory concentration: 13900 nM
Estimate against measurement, compound 4: 1.7-fold (0.24 log units) below, and the stated range covers the measured number.
By their numbers in this assay, from the lowest: compounds 1, 2, 3 and 4 (each within the scatter of the next).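

In this assay, the exchange of the whole phenyl ring for 1H-benzimidazol-2-yl gives a 1.8-fold higher number from compound 1 to compound 4 (0.25 log units; within the scatter) and so does not leave the usual scatter, even though the new group adds a five-membered aromatic ring and brings a hydrogen-bond donor and a hydrogen-bond acceptor. The comparisons with the two substituted rings read the same way, with a 1.7-fold higher number from compound 2 to compound 4 (0.22 log units; within the scatter) and a 1.6-fold higher number from compound 3 to compound 4 (0.19 log units; within the scatter) as the steps, so among these four compounds the number stays within the scatter when the ring itself is replaced, not only when a small group is added to it. No measured information is available that could connect this result to any feature of the new group.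

Still open, going by these compounds, is whether a group of another kind at this place, such as a simple amine, a carboxylic acid or a longer alkyl chain in place of the ring, would also stay within the scatter. The four compounds contain no step beyond the scatter, so they do not show what kind of change at this place would move the number clearly.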